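A few compounds are considered here, and "the series" means these few. Any claim that something is new, unique, unknown or untested is made for them only; others in the source may bear on it.

Compound 1, `COc1ccc(CNc2nc(SC)nc3ncccc23)cc1`, was tested in a functional assay on CCRF-CEM cells (Homo sapiens) for cytotoxicity, read by MTT assay, with a stated time of 72 h (a higher number here means a weaker inhibitor of growth, a lower number a stronger inhibitor of growth), where compound 1 gives > 100000 nM, which is a limit of the assay and not a number. Compound 2, `CCCCCSc1nc(NCc2ccc([Se]C)cc2)c2ccccc2n1`, gives > 100000 nM in this assay, again a limit rather than a measured number. Compound 2 therefore stands where both values shown stand: the limit of > 100000 nM in this assay, at which 2 of the 2 values shown sit. Compound 3, `CSc1nc(NCc2ccc([Se]C)cc2)c2ccccc2n1`, is still to be measured in this assay. It differs from compound 2 by hydrogen in place of butyl on a saturated chain carbon bound to a sulfur. Going by the values given here, no step between measured compounds is available to size this change, and the two values shown are both limits. The step expected from compound 2 to compound 3 is a number no higher from compound 2 to compound 3 (the limit leaves the size open), nothing beyond the scatter. Compound 3 is estimated at 100000 nM, with a range from 30000 nM to 300000 nM, and most likely the assay again reports only a limit.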

Compound 3, concentration for total growth inhibition: > 100000 nM
Compound 3: only a limit was reported; the forecaster's own chance of this, stated with the estimate: 80%; the middle value lies on the limit itself.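

Compound 2 and compound 3 each carry only a limit in this assay, so no step can be read for the change from pentyl to methyl. The compounds shown leave open whether any single change would yield a measured number, as all stand at one place: the limit of > 100000 nM in this assay, at which 3 of the 3 values shown sit.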